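The compounds below may be only part of what the source reports. "The series", "measured", "known", "first", "only" and "open" are said of these compounds alone.

Compound 1 `CCOC(=O)[C@H](CCC(=O)O)NC(=O)c1ccc(Oc2nc3cc(N)cc(N)c3nc2-c2ccccc2)cc1`, compound 2 `Nc1cc(N)c2nc(-c3ccccc3)c(NCc3ccc(F)cc3)nc2c1` and compound 3 `COc1ccc(Sc2nc3cc(N)cc(N)c3nc2-c2ccccc2)cc1` share one core. In a functional assay on UO-31 cells (Homo sapiens) for inhibition, read by sulforhodamine B assay, with a stated time of 48 h (a higher number here means that more compound is tolerated, a lower number that less compound is tolerated), compound 1 gives < 50200 nM, which is a limit of the assay and not a number. In this assay compound 2 gives < 100000 nM, again a limit. In this assay compound 3 gives < 100000 nM, also a limit. Compound 3 thus stands at the limit of < 100000 nM in this assay, at which 2 of the 3 values shown sit, while compound 1 alone sits at the limit of < 50200 nM in this assay, at which 1 of the 3 values shown sits. The step that the two limits leave unreadable from compound 2 to compound 3 cannot be sized. Compound 4 `Nc1cc(N)c2nc(-c3ccccc3)c(Oc3ccc(F)cc3)nc2c1` differs from compound 3 by 4-fluorophenoxy in place of (4-methoxyphenyl)sulfanyl on an aromatic carbon. No readable step in this assay bears on this change, so no step beyond the scatter is expected, and a limit remains the likeliest outcome. Compound 4 is therefore estimated at 100000 nM, between 30000 nM and 300000 nM, an expected step of a number no lower from compound 3 to compound 4 (the limit leaves the size open).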

Compound 4, concentration lethal to 50% of the cells: < 100000 nM
Compound 4 was reported as a limit; the forecaster's own chance of this, stated with the estimate: 75%; the middle value sits exactly at the limit.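

Compound 4, like compound 2 and compound 3, is reported only as a limit, so no step among them can be read in this assay: the limit of < 100000 nM in this assay, at which 3 of the 4 values shown sit.

The compounds shown leave open how 4-fluorophenoxy, (4-methoxyphenyl)sulfanyl and (4-fluorobenzyl)amino compare on the shared core.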